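The source may report more compounds than this note shows. Statements on the series, on what has been measured and on what is new or still open speak of the compounds shown alone.

Measured so far:
compound 1, `c1ccc(CCc2ccc3c(NCCCNCc4ccco4)ccnc3c2)cc1`: 23 10^-6 cm/s
compound 2, `FC(F)(F)c1cc(-c2ccc3c(NCCCNCc4ccco4)ccnc3c2)cc(C(F)(F)F)c1`: 237 10^-6 cm/s
compound 3, `COc1ccc(F)cc1CNCCCNc1ccnc2cc(Cc3ccccc3)ccc12`: 23 10^-6 cm/s

In an ADME assay for permeability, using PAMPA, with a stated time of 30 min, at pH 7.4 (a lower number here means that the compound crosses the layer more slowly, a higher number that the compound crosses the layer faster), compound 1 gives 23 10^-6 cm/s, level with compound 3 at the digits shown; together these two are the lowest of the three numbers, and their gap lies within the scatter. Compound 2 reads 237 10^-6 cm/s, a step beyond the scatter above compound 1.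

Compound 4, `COc1ccc(-c2ccc3c(NCCCNCc4ccco4)ccnc3c2)cc1`, is not yet measured. It differs from compound 1 in one place: 4-methoxyphenyl in place of phenethyl on an aromatic carbon. Among the measured compounds shown here, no measured pair shows this exact change, so the size of the step is open. For the measured compounds named here, the only pointer is compound 2, whose substituent is likewise one six-membered aromatic ring of carbon only, at 237 10^-6 cm/s. For compound 4 the expected step is a 2.0-fold higher number from compound 1 to compound 4 (0.29 log units; within the scatter), modest and upward. The estimate for compound 4 is 45 10^-6 cm/s, with a range of 15 10^-6 cm/s to 140 10^-6 cm/s.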

Compound 4, apparent permeability: 237 10^-6 cm/s
Compound 4: the middle estimate sits 5.3-fold (0.72 log units) below what was measured; measured number above the stated range.
By their numbers in this assay, from the lowest: compounds 1 and 3 (each within the scatter of the next); then compounds 2 and 4 (each within the scatter of the next).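

In this assay this position proves sensitive: 4-methoxyphenyl in place of phenethyl gives a 10-fold higher number from compound 1 to compound 4 (1.01 log units; beyond the scatter) even though both groups hold 8 heavy atoms and one six-membered aromatic ring of carbon only. Compound 2 gives 237 10^-6 cm/s and compound 4 gives 237 10^-6 cm/s with the two values within the scatter of each other. No measurement at hand accounts for the step.

Still open, going by these compounds, is how an amine or a carboxylic acid on the incoming ring would read. On these data alone, a longer chain at this aromatic carbon also remains open.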